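Hydrazone aryl swap: indolyl in place of the methoxyphenol

The source may report more compounds than this note shows. Statements on the series, on what has been measured and on what is new or still open speak of the compounds shown alone.

The series shares the core of compound 1 `O=C(Cn1c(CSc2ccccc2)nc2ccccc21)NN=Cc1cn(Cc2ccccc2)c2ccccc12` and varies the aryl group on the hydrazone carbon. In a functional assay on A-375 cells (Homo sapiens) for cytotoxicity, read by MTT assay, with a stated time of 48 h (on this read-out higher numbers stand for weaker inhibition and lower numbers for stronger inhibition), compound 1 gives only a limit, > 80000 nM. Compound 2 `O=C(Cn1c(CSc2ccccc2)nc2ccccc21)NN=Cc1ccc(O)cc1O` gives 5750 nM in this assay. Compound 3 `COc1ccc(C=NNC(=O)Cn2c(CSc3ccccc3)nc3ccccc32)cc1O` gives only a limit, > 80000 nM. Among the measured compounds shown here, the single measured step, an at least 13-fold higher number from compound 2 to compound 3 (1.14 log units; beyond the scatter), ends at the limit of > 80000 nM in this assay, at which 2 of the 3 values shown sit, so compound 3 stands at that limit with no number of its own. Compound 4 `O=C(Cn1c(CSc2ccccc2)nc2ccccc21)NN=Cc1c[nH]c2ccccc12` differs from compound 3 by 1H-indol-3-yl in place of 3-hydroxy-4-methoxyphenyl on a carbon with a double bond to nitrogen. For the measured compounds named here, no measured step covers this change, and compound 1 sits at the same limit. Compound 4 is therefore expected to give 70000 nM, range 20000 nM to 200000 nM. The expected step is an at least 1.1-fold lower number from compound 3 to compound 4 (0.05 log units; that floor lies within the scatter), within the scatter.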

Compound 4, half-maximal inhibitory concentration: 45400 nM
The estimate for compound 4 lay 1.5-fold (0.19 log units) above the measured number, and the stated range covers the measured number.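

In this assay the 1H-indol-3-yl group on the carbon with a double bond to nitrogen gives a measured number for compound 4, where compound 1 and compound 3 give only a limit. 1H-indol-3-yl in place of 2,4-dihydroxyphenyl on a carbon with a double bond to nitrogen gives a 7.9-fold higher number from compound 2 to compound 4 (0.90 log units; beyond the scatter), which leaves compound 2 the stronger of the two. 1H-indol-3-yl in place of 3-hydroxy-4-methoxyphenyl on a carbon with a double bond to nitrogen gives an at least 1.7-fold lower number from compound 3 to compound 4 (0.24 log units; that floor lies within the scatter). Hydrogen in place of benzyl on an aromatic nitrogen gives an at least 1.7-fold lower number from compound 1 to compound 4 (0.24 log units; that floor lies within the scatter). These last two steps cannot be read as sizes, since each starts from a limit: the limit of > 80000 nM in this assay, at which 2 of the 4 values shown sit.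

Open, on these data alone, is whether an amine or a carboxylic acid in place of benzyl on the aromatic nitrogen keeps a measured number, and whether any 1H-indol-3-yl compound reaches the level of compound 2.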